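Swapping the Pyridine Attachment Point on an Adenosine Ligand

The source may hold more compounds than are shown below. What is called first, only, known or untested is meant among the compounds shown, and "the series" means these compounds.

Of the compounds shown here, three have been measured in an assay on CHO cells for displacement of a labelled ligand from adenosine receptor A3 (Homo sapiens), read by scintillation counting, with a stated time of 120 min; on this read-out higher numbers stand for weaker inhibition and lower numbers for stronger inhibition. Compound 1 `Nc1nc(NCc2cccnc2)nc2sc(-c3ccco3)nc12` gives 18.2 nM. For the measured compounds named here, compound 3 `Cc1ccc(-c2nc3c(N)nc(NCc4cccs4)nc3s2)o1` gives 15.3 nM, a number that sits within the usual scatter of the one for compound 1, so the two cannot be told apart. Compound 2 `COc1ccccc1CNc1nc(N)c2nc(-c3cccs3)sc2n1` gives 275 nM, a clearly higher number than that of compound 1, and this gap does lie beyond the scatter. Compound 1 thus stands with the second highest of the three numbers, close to compound 3 and far from compound 2.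

Compound 4 `Nc1nc(NCc2ccccn2)nc2sc(-c3ccco3)nc12` has not yet been measured. It shares every atom with compound 1 and differs only in how they are joined: pyridin-2-yl in place of pyridin-3-yl on a saturated chain carbon bound to a nitrogen on an aromatic ring. Going by the values given here, no measured pair shows this kind of change, so its effect has to be guessed. Because compound 1 gives 18.2 nM and the change is small, the step from compound 1 to compound 4 is expected to be modest, a 1.6-fold higher number from compound 1 to compound 4 (0.22 log units; within the scatter), with a slightly higher number somewhat more likely than a lower one. Compound 4 is therefore estimated at 30 nM, with a plausible range from 8 nM to 120 nM.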

Compound 4, inhibition constant: 59 nM
Compound 4: middle estimate off by 2.0-fold (0.29 log units), on the low side, within the range that was stated.
By their numbers in this assay, from the lowest: compounds 3 and 1 (each within the scatter of the next); then compound 4; then compound 2.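

Changing only how the pyridine ring is joined, with no atom added or removed, is enough to shift the result in this assay: pyridin-2-yl in place of pyridin-3-yl gives a 3.2-fold higher number from compound 1 to compound 4 (0.51 log units; beyond the scatter). For the compounds shown here, this is the only pair here that differs in one place, so it gives the first direct reading of this position, on a saturated chain carbon bound to a nitrogen on an aromatic ring. It shows that this position responds to the attachment point of the ring and not just to which atoms are present, though no measurement here accounts for the size or direction of the step.

The compounds shown leave open how pyridin-4-yl or a plain phenyl at the same place would compare with these two pyridines. Going by these compounds, whether the same step would appear with a different group elsewhere on the core also remains open.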